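Replacing 2,5-difluorophenyl with 4-ethylcyclohexyl on a shared core

The source may report more compounds than this note shows. Statements on the series, on what has been measured and on what is new or still open speak of the compounds shown alone.

- Compound 1 `OC[C@@H]1[C@@H](O)[C@H](O)[C@@H](O)CN1CC/C=C/CCOc1cc(F)ccc1F` gives > 500000 nM (a limit)
- Compound 2 `OC[C@@H]1[C@@H](O)[C@H](O)[C@@H](O)CN1CCCCCCOc1cc(F)ccc1F` gives > 500000 nM (a limit)

In an ADME assay on BHK cells (Mesocricetus auratus) for cytotoxicity, read by MTT assay (a higher number here means that more compound is tolerated, a lower number that less compound is tolerated), compound 2 gives > 500000 nM as a limit of the measurement, not as a number. Neither measured compound gives an exact value (the limit of > 500000 nM in this assay, at which 2 of the 2 values shown sit). Compound 3 `CCC1CCC(OCCCCCCN2C[C@H](O)[C@@H](O)[C@H](O)[C@H]2CO)CC1` has 4-ethylcyclohexyl in place of 2,5-difluorophenyl on an oxygen on a saturated carbon. Among the measured compounds shown here, no measured step guides the size of this change, so only a modest loss of tolerance is expected, and another limit is quite possible. The estimate expects a modest drop (an at least 1.4-fold lower number from compound 2 to compound 3 (0.15 log units; that floor lies within the scatter)). Compound 3 is expected at 350000 nM with an estimated range of 120000 nM to 500000 nM for now.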

Compound 3, half-maximal cytotoxic concentration: 475000 nM
Compound 3: middle estimate off by 1.4-fold (0.13 log units), on the low side, within the range that was stated.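

In this assay compound 3 gives 475000 nM as the only exact value among the compounds shown, so 4-ethylcyclohexyl on this oxygen leaves the compound well tolerated. The change comes to an at least 1.0-fold lower number from compound 2 to compound 3 (0.02 log units; that floor lies within the scatter) and only that floor is known. From the compounds shown here alone, the true size of the step stays open because compound 2 stands at a limit of the assay: the limit of > 500000 nM in this assay, at which 2 of the 3 values shown sit.

Going by these compounds, whether tolerance holds with an amine or a carboxylic acid on the cyclohexyl ring remains open. So does the effect of a longer chain in place of the ethyl group.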